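A chain-linked ring on the amide nitrogen

The compounds below may be only part of what the source reports. "The series", "measured", "known", "first", "only" and "open" are said of these compounds alone.

In an ADME assay on S9 fraction from liver (Rattus norvegicus) for metabolic stability, with a stated time of 60 min (a lower number here means that less of the compound is left, a higher number that more of the compound is left), compound 1 `Cc1nc(-c2nc[nH]n2)ccc1-c1cnc2c(n1)N([C@H]1CC[C@@H](O)CC1)C(=O)CN2` gives 100%, compound 2 `CO[C@H]1CC[C@@H](CN2C(=O)CNc3ncc(-c4ccc(-c5nc[nH]n5)nc4C)nc32)CC1` gives 39% and compound 3 `CO[C@H]1CC[C@H](N2C(=O)CNc3ncc(-c4ccc(-c5nc[nH]n5)nc4C)nc32)CC1` gives 72%, second highest of the three. Compound 4 `Cc1nc(-c2nc[nH]n2)ccc1-c1cnc2c(n1)N(CCC1CCOCC1)C(=O)CN2` differs from compound 3 in one place: 2-(oxan-4-yl)ethyl in place of 4-methoxycyclohexyl on an amide-type nitrogen in a ring. The closest evidence is the large step of a number 33 percentage points higher from compound 2 to compound 3 (beyond the scatter), where 4-methoxycyclohexyl replaces (4-methoxycyclohexyl)methyl. Among the compounds with values here, compound 4 again has a chain-linked ring there, so a large step in the opposite direction is expected, though no measured compound carries an oxane ring. The expected change is a number 30 percentage points lower from compound 3 to compound 4 (beyond the scatter). For compound 4 the estimated value is 42%, within an expected range of 22% to 68%.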

Compound 4, percent of the compound remaining: 76%
Beside the measured number, compound 4's estimate is 34 percentage points below it; the measured number lies above the stated range.
By their numbers in this assay, from the lowest: compound 2; then compounds 3 and 4 (each within the scatter of the next); then compound 1.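

In this assay, a chain-linked ring on the amide-type nitrogen need not lower the number: with 2-(oxan-4-yl)ethyl there is a number 4 percentage points higher from compound 3 to compound 4 (within the scatter). The chain link alone therefore does not account for the low number of compound 2, given a number 37 percentage points higher from compound 2 to compound 4 (beyond the scatter). Compound 1 with its 4-hydroxycyclohexyl still stands apart, with a number 24 percentage points lower from compound 1 to compound 4 (beyond the scatter).

Going by these compounds, how a simple amine or a carboxylic acid at the end of this chain would fare remains open. Nothing at hand explains the gap between compound 2 and compound 4, where ring and chain change together.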